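Trimming the Sulfonamide Tail: Hydroxyethyl to Methyl

This account rests on a few compounds, and the source may have more. Where it says the series, first, only, none or still open, it means among the compounds named here.

Compound 1 `CC[C@@H]1C(=O)N(C)c2cnc(Nc3ccc(S(=O)(=O)NCCO)cc3)nc2N1C1CCCC1`: 344 nM
Compound 2 `CC[C@@H]1C(=O)N(C)c2cnc(-n3ccc4cc(C(=O)NC5CCCC5)ccc43)nc2N1C1CCCC1`: 795 nM

Among the compounds with values here, in a functional assay on MCF7 cells (Homo sapiens) for antiproliferative activity, read by CCK-8 assay, with a stated time of 72 h (on this read-out higher numbers stand for weaker inhibition of growth and lower numbers for stronger inhibition of growth), compound 1 gives 344 nM, the lower of the two numbers known so far, while compound 2 gives 795 nM, a gap that lies beyond the usual scatter. Compound 3 `CC[C@@H]1C(=O)N(C)c2cnc(Nc3ccc(S(=O)(=O)NC)cc3)nc2N1C1CCCC1` has not yet been measured. It differs from compound 1 by hydrogen in place of hydroxymethyl on a saturated chain carbon bound to a sulfonamide nitrogen. Within the data shown here, with no comparable step among the measured pair, the change is expected to move the number little, with an estimated step from compound 1 to compound 3 of a 1.3-fold higher number from compound 1 to compound 3 (0.12 log units; within the scatter), not beyond the scatter. Compound 3 is therefore expected to give about 450 nM, within a range of 200 nM to 1000 nM.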

Compound 3, concentration for 50% growth inhibition: 151 nM
For compound 3 the middle estimate is 3.0-fold (0.47 log units) above the measured one; measured number below the stated range.
By their numbers in this assay, from the lowest: compound 3; then compound 1; then compound 2.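

In this assay, the change from (2-hydroxyethyl)sulfamoyl to methylsulfamoyl gives a 2.3-fold lower number from compound 1 to compound 3 (0.36 log units; beyond the scatter), the first step read at this position. It shows that growth inhibition here does not depend on the hydroxymethyl on the saturated chain carbon bound to a sulfonamide nitrogen, and that the shorter methyl group gives the stronger inhibition of this pair. Nothing available explains this step.

The compounds shown leave open whether a longer chain, a terminal amine or a carboxylic acid on that sulfonamide nitrogen would continue this trend or reverse it.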